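Chloro in place of methoxy in compound 4

A few compounds are considered here, and "the series" means these few. Any claim that something is new, unique, unknown or untested is made for them only; others in the source may bear on it.

Results so far in a functional assay on CCRF-CEM cells (Homo sapiens) for antiproliferative activity, read by cell counting, with a stated time of 2 days (a lower number here means a stronger inhibitor, a higher number a weaker inhibitor), are these.
Compound 1 `COc1cc(C(=O)c2sc(Nc3ccccc3)nc2N)cc(OC)c1OC` gives 9.4 nM here
Compound 2 `COc1ccc(C(=O)c2sc(Nc3ccccc3)nc2N)cc1OC` gives 6900 nM here
Compound 3 `COc1ccc(Nc2nc(N)c(C(=O)c3ccccc3)s2)cc1` gives 300 nM here

Compound 3 holds the middle place among these three numbers, with compound 1 lower and compound 2 higher. Compound 4 `Nc1nc(Nc2ccc(Cl)cc2)sc1C(=O)c1ccccc1` has chloro in place of methoxy on an aromatic carbon of compound 3 chloro in place of methoxy on an aromatic carbon and the change sits para to a large group.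

Within the data shown here, no measured step swaps methoxy for chloro. The closest is a 730-fold higher number from compound 1 to compound 2 (2.87 log units; beyond the scatter) and that large step puts hydrogen in place of methoxy on an aromatic carbon. It concerns a different methoxy and a different partner group, so it guides the direction only loosely. Resting on a 730-fold higher number from compound 1 to compound 2 (2.87 log units; beyond the scatter) as that weak guide, a moderate rise in the number is expected in this assay and a change within the scatter remains possible. The expected change is a 2.7-fold higher number from compound 3 to compound 4 (0.43 log units; beyond the scatter) as an estimate. For compound 4 the estimated value is 800 nM with an expected range from 150 nM to 4000 nM in all.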

Compound 4, half-maximal inhibitory concentration: > 10000 nM
Compound 4 was reported as a limit; the forecaster's own chance of this, stated with the estimate: 10%; middle value at least 12-fold (1.09 log units) away from the limit.
By their numbers in this assay, from the lowest: compound 1; then compound 3; then compound 2. At a limit, above all of these: compound 4.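

Compound 4 gives > 10000 nM in this assay, and this is a limit of the assay, not a number. Chloro in place of methoxy on this aromatic carbon, para to a large group, gives an at least 33-fold higher number from compound 3 to compound 4 (1.52 log units; beyond the scatter), which shows that activity depends strongly on what sits at this position, whereas the one earlier step concerned a different methoxy and a different partner group. The true size of this step remains unknown, and only its lower bound can be read: the limit of > 10000 nM in this assay, at which 1 of the 4 values shown sits.

The compounds shown leave open whether the loss comes from chloro itself or from the absence of methoxy, and how an amine, a methyl or a longer ether chain would behave at this position. They also leave open whether chloro here would cost as much with the trimethoxy-bearing partner group of compound 1.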